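Fluorine on the phenylthiazole arm: an expectation for compound 4

This account rests on a few compounds, and the source may have more. Where it says the series, first, only, none or still open, it means among the compounds named here.

Compound 1 `Cc1noc(C)c1-c1ccc2c(c1)C(c1ccccc1)N(Cc1ncc(-c3ccccc3)o1)C(=O)N2C` gives 50.6% in a functional assay on HepG2 cells (Homo sapiens) for inhibition, read by MTT assay, with a stated time of 48 h, tested at 2 uM; on this read-out lower numbers stand for less inhibition and higher numbers for more inhibition at the one concentration tested (going by the name of the read-out).
Compound 2 `Cc1noc(C)c1-c1ccc2c(c1)C(c1ccccc1)N(Cc1nnc(-c3ccccc3)s1)C(=O)N2C` gives 35.2% in this assay.
Compound 3 `Cc1noc(C)c1-c1ccc2c(c1)C(c1ccccc1)N(Cc1nc(-c3ccccc3)cs1)C(=O)N2C` gives 44.5% in this assay.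

Compound 3 sits between the other two; its gaps, a number 6.1 percentage points lower from compound 1 to compound 3 (within the scatter) and a number 9.3 percentage points higher from compound 2 to compound 3 (within the scatter), both lie within the usual scatter, so the three cannot be ranked with confidence. Compound 4 `Cc1noc(C)c1-c1ccc2c(c1)C(c1ccccc1)N(Cc1nc(-c3ccc(F)cc3)cs1)C(=O)N2C` differs from compound 3 only by fluoro in place of hydrogen on an aromatic carbon. For the measured compounds named here, every measured step, including a number 15.4 percentage points lower from compound 1 to compound 2 (beyond the scatter), swaps the whole ring on the saturated chain carbon; none touches the phenyl, so no measured step bears directly on this change. A small step is therefore expected, a number 0.5 percentage points higher from compound 3 to compound 4 (within the scatter), not beyond the scatter. Compound 4 is estimated at 45%, expected between 30% and 60%.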

Compound 4, a percentage reported as inhibition, at one concentration (the size of the read-out at that concentration, not a potency): 41.1%
Estimate against measurement, compound 4: 3.9 percentage points above; measured number inside the range.
By their numbers in this assay, from the lowest: compounds 2, 4, 3 and 1 (each within the scatter of the next, the first and the last beyond it).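

In this assay the change on the phenyl itself, fluoro para to a large group, gives a number 3.4 percentage points lower from compound 3 to compound 4 (within the scatter) and so leaves the number within the usual scatter. The steps of a number 5.9 percentage points higher from compound 2 to compound 4 (within the scatter) and a number 9.5 percentage points lower from compound 1 to compound 4 (within the scatter) are also within the scatter, so compound 4 cannot be ordered against either of those ring swaps. No measurement shown here offers an explanation for these numbers. As far as these compounds go, whether a larger group at the same place, such as a methoxy group, an amine or a carboxylic acid, would move the number beyond the scatter stays open. Also open, from the compounds shown here alone, is whether fluoro would do the same on the 5-phenyl-1,3-oxazol-2-yl arm.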